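Adding a methyl to the saturated ring of compound 2

The compounds below may be only part of what the source reports. "The series", "measured", "known", "first", "only" and "open" are said of these compounds alone.

In an ADME assay on microsomes from liver (Homo sapiens) for metabolic stability, read by LC-MS, with a stated time of 60 min (on this read-out lower numbers stand for a less stable compound and higher numbers for a more stable compound), compound 1 `NC(=O)c1cnc2c(c1)CCN2` gives 100%, compound 2 `Cc1c(C(N)=O)cnc2c1CCN2` gives 85% and compound 3 `NC(=O)c1cnc2c(c1Cl)CCN2` gives 57%. Compound 2 therefore holds the second highest of the three numbers, with compound 1 above it and compound 3 below it.

Compound 4 `Cc1c(C(N)=O)cnc2c1C[C@@H](C)N2` carries one change from compound 2: methyl in place of hydrogen on a saturated ring carbon. The methyl takes the place of hydrogen on a saturated ring carbon, next to the ring nitrogen.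

Within the data shown here, no measured step involves this saturated ring carbon. The closest comparison is methyl in place of hydrogen on an aromatic carbon, which gave a number 15 percentage points lower from compound 1 to compound 2 (beyond the scatter). Among the measured compounds shown here, the chloro steps, a number 43 percentage points lower from compound 1 to compound 3 (beyond the scatter) and a number 28 percentage points lower from compound 2 to compound 3 (beyond the scatter), involve a different group and show only that single changes on an aromatic carbon have moved this number downward by varying amounts.

A modest fall is expected, though its size is uncertain at this new place. The estimated step is a number 13 percentage points lower from compound 2 to compound 4 (beyond the scatter). The expected value for compound 4 is 72%, within an estimated range of 50% to 90%.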

Compound 4, percent of the compound remaining: 91%
Estimate against measurement, compound 4: 19 percentage points below; measured number above the stated range.
By their numbers in this assay, from the lowest: compound 3; then compounds 2, 4 and 1 (each within the scatter of the next, the first and the last beyond it).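

In this assay, methyl in place of hydrogen on a saturated ring carbon, next to the ring nitrogen, gives a number 6 percentage points higher from compound 2 to compound 4 (within the scatter) and so leaves no change that can be told from the usual scatter. The earlier steps were all on an aromatic carbon and all lay beyond the scatter, among them a number 15 percentage points lower from compound 1 to compound 2 (beyond the scatter) for the same methyl group, so this saturated ring carbon is the one place shown where a methyl can be added with no readable effect on this number. Nothing at hand accounts for the difference between the two places.

Open, as far as these compounds go, is whether a longer chain such as ethyl, or a polar group such as a hydroxymethyl or an amine, would read the same on this carbon. Also open, from the compounds shown here alone, is whether the mirror-image arrangement of the methyl, or the same methyl on the core of compound 1, would stay as close to its parent.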